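Replacing thiophen-3-yl with 4-chlorophenyl on a carbonyl

The source may report more compounds than this note shows. Statements on the series, on what has been measured and on what is new or still open speak of the compounds shown alone.

Compound 1 (`CN1CCC(C(=O)N2Cc3c(NC(=O)NCc4ccccc4)n[nH]c3C2(C)C)CC1`) and compound 2 (`CN1CCC(C(=O)N2Cc3c(NC(=O)c4ccsc4)n[nH]c3C2(C)C)CC1`) share a core and differ only in the group on a carbonyl carbon. In a functional assay on A2780 cells (Homo sapiens) for antiproliferative activity, read by fluorescence, with a stated time of 72 h (on this read-out higher numbers stand for weaker inhibition and lower numbers for stronger inhibition), compound 1 gives 2680 nM and compound 2 gives 140 nM, so compound 2 holds the lower, stronger number of the pair. Compound 3 (`CN1CCC(C(=O)N2Cc3c(NC(=O)c4ccc(Cl)cc4)n[nH]c3C2(C)C)CC1`) changes that same place: 4-chlorophenyl in place of thiophen-3-yl on a carbonyl carbon. In words, 4-chlorophenyl stands in place of thiophen-3-yl on a carbonyl carbon. Within the data shown here, only one measured step bears on this, a 19-fold lower number from compound 1 to compound 2 (1.28 log units; beyond the scatter), a large change made at the same carbonyl carbon. It shows that this place can move the number a long way, but it replaced benzylamino, not one aromatic ring with another. Among the measured compounds shown here, no measured pair tests a swap of that kind, so a jump of similar size is not expected. In this assay the expected change is small, with a 1.4-fold higher number from compound 2 to compound 3 (0.13 log units; within the scatter) as the estimate, slightly upward and within the scatter. For compound 3 the estimated value is 190 nM, with an expected range from 60 nM to 600 nM.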

Compound 3, half-maximal inhibitory concentration in the A2780 assay: 120 nM
Compound 3: the middle estimate sits 1.6-fold (0.20 log units) above what was measured; the measured number falls inside the stated range.
By their numbers in the A2780 assay, from the lowest: compounds 3 and 2 (each within the scatter of the next); then compound 1.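

In the A2780 assay, exchanging one aromatic ring for another on this carbonyl carbon gives a 1.2-fold lower number from compound 2 to compound 3 (0.07 log units; within the scatter), so a five-membered ring containing sulfur and a six-membered carbon ring carrying chlorine cannot be told apart here. Measured against benzylamino, 4-chlorophenyl gives a 22-fold lower number from compound 1 to compound 3 (1.35 log units; beyond the scatter), which shows that the large step seen earlier with thiophen-3-yl is not unique to that ring: two different aromatic rings now stand well apart from the benzylamino group of compound 1. In a physicochemical assay for solubility, at pH 7 (on this read-out higher numbers stand for higher solubility and lower numbers for lower solubility), compound 2 gives > 225000 nM, which is a limit of the assay and not a number. In the physicochemical assay compound 3 gives > 225000 nM, which is also a limit of the assay and not a number. In the physicochemical assay the step from compound 2 to compound 3 cannot be read, and no solubility difference can be drawn from it, because both compounds sit at a limit of the assay rather than at a number: the limit of > 225000 nM in the physicochemical assay, at which 2 of the 2 values shown sit.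

From the compounds shown here alone, whether this carbonyl carbon needs an aromatic ring at all stays open, and a cyclohexyl ring or a plain propyl chain in that place would put this to the test. Also open, going by these compounds, is how far the tolerance for different rings extends in the A2780 assay, for instance to a pyridine ring or to a phenyl ring carrying a carboxylic acid or an amine.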